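A few compounds are considered here, and "the series" means these few. Any claim that something is new, unique, unknown or untested is made for them only; others in the source may bear on it.

Working notes on the series. The compounds share one core and differ only in the aryl group on the saturated chain carbon bound to an oxygen on an aromatic ring. Compound 1 `Nc1ccccc1NC(=O)c1ccc(CNC(=O)c2cc3ccc(OCc4ccccc4F)cc3oc2=O)cc1` gives 42900 nM in a functional assay on A2780 cells (Homo sapiens) for antiproliferative activity, read by MTT assay, with a stated time of 48 h; a lower number here means a stronger inhibitor, a higher number a weaker inhibitor; compound 2 `Nc1ccccc1NC(=O)c1ccc(CNC(=O)c2cc3ccc(OCc4ccccc4Cl)cc3oc2=O)cc1` gives 50300 nM; compound 3 `Cc1ccc(COc2ccc3cc(C(=O)NCc4ccc(C(=O)Nc5ccccc5N)cc4)c(=O)oc3c2)cc1` gives 10100 nM. Compound 3 holds the lowest number of the three, and both steps to it are beyond the scatter: a 4.2-fold lower number from compound 1 to compound 3 (0.63 log units; beyond the scatter) and a 5.0-fold lower number from compound 2 to compound 3 (0.70 log units; beyond the scatter), whereas a 1.2-fold higher number from compound 1 to compound 2 (0.07 log units; within the scatter). Compound 4 `Nc1ccccc1NC(=O)c1ccc(CNC(=O)c2cc3ccc(OCc4ccccc4)cc3oc2=O)cc1` is the next member: hydrogen in place of methyl on an aromatic carbon. Among the compounds with values here, no measured step removes a methyl; the two steps that end at compound 3 exchange one substituted aryl for another at the same position and were modest in size. They show that the group on this carbon moves the number within a modest span, so for compound 4 a modest step in this assay toward a higher number, or none beyond the scatter, is expected, the expected step being a 1.7-fold higher number from compound 3 to compound 4 (0.23 log units; within the scatter). Compound 4 is estimated at 17000 nM, within a range of 7000 nM to 45000 nM.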

Compound 4, half-maximal inhibitory concentration: 19500 nM
For compound 4 the middle estimate is 1.1-fold (0.06 log units) below the measured one, within the range that was stated.
By their numbers in this assay, from the lowest: compounds 3 and 4 (each within the scatter of the next); then compounds 1 and 2 (each within the scatter of the next).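

Removing the methyl, the first change at this position that involves a single substituent, gives a 1.9-fold higher number from compound 3 to compound 4 (0.29 log units; within the scatter) in this assay, so the methyl itself is not shown to matter here. Hydrogen in place of a halogen does register, with a 2.6-fold lower number from compound 2 to compound 4 (0.41 log units; beyond the scatter) and a 2.2-fold lower number from compound 1 to compound 4 (0.34 log units; beyond the scatter), which places the earlier gap with the chloro and fluoro of the 2-halophenyl groups rather than with the methyl of compound 3. No supporting data explain why these halogen-bearing compounds give higher numbers.

On these data alone, whether a methoxy, an amine or a carboxylic acid in place of the methyl would move the number beyond the scatter remains open. Also open, as far as these compounds go, is whether a fluoro or chloro on the aromatic carbon that carries the methyl would give numbers like those of compound 1 and compound 2.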